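A Saturated Ring Replaces an Aromatic One on the Amide Arm

The source may report more compounds than this note shows. Statements on the series, on what has been measured and on what is new or still open speak of the compounds shown alone.

Measured compounds:
Compound 1, `C[C@@H]1CN(c2sc(C(F)(F)F)nc2-c2nc3ccccc3[nH]2)CCN1C(=O)Cn1cc(Cl)cn1`: 1.7 nM
Compound 2, `Cc1nc(C)n(CC(=O)N2CCN(c3sc(C(F)(F)F)nc3-c3nc4ccc(S(C)(=O)=O)cc4[nH]3)C[C@H]2C)n1`: 10 nM

In a functional assay on CHO-K1 cells for antagonist activity at C-X-C chemokine receptor type 3 (Homo sapiens), read by FLIPR, with a stated time of 10 min, in the presence of a further agent that is not named here (a lower number here means a stronger inhibitor, a higher number a weaker inhibitor), compound 1 gives 1.7 nM, the lower of the two numbers; compound 2 gives 10 nM, a higher number, and the gap between them lies beyond the usual scatter. The two compounds differ in more than one place, so no single step can be read from them.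

Compound 3, `COC1CCN(CC(=O)N2CCN(c3sc(C(F)(F)F)nc3-c3nc4ccccc4[nH]3)C[C@H]2C)C1`, is not yet measured. It differs from compound 1 in one place: 3-methoxypyrrolidin-1-yl in place of 4-chloro-1H-pyrazol-1-yl on a saturated chain carbon bound to a carbonyl carbon

Going by the values given here, no measured pair shows this change, so its effect is unknown from the data. A step toward a higher number is expected, a 4.7-fold higher number from compound 1 to compound 3 (0.67 log units; beyond the scatter), since the fused aromatic portion and the core of compound 1 are unchanged and only the amide arm moves from a five-membered aromatic ring to a five-membered non-aromatic ring. Compound 3 is therefore estimated at 8 nM, within a range from 2 nM to 35 nM.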

Compound 3, half-maximal inhibitory concentration: 42 nM
The estimate for compound 3 lay 5.3-fold (0.72 log units) below the measured number, and the stated range ends below it.
By their numbers in this assay, from the lowest: compound 1; then compound 2; then compound 3.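

In this assay the amide arm proves sensitive at this position: 3-methoxypyrrolidin-1-yl in place of 4-chloro-1H-pyrazol-1-yl on a saturated chain carbon bound to a carbonyl carbon brings a 25-fold higher number from compound 1 to compound 3 (1.39 log units; beyond the scatter) with the rest of compound 1 unchanged. The step is large even though a five-membered ring, the counts of hydrogen-bond donors and acceptors and the absence of net charge all stay the same, while the ring ceases to be aromatic and the chlorine gives way to a methoxy group. No measurement here accounts for the loss.

Which of these differences carries the step remains open. An unsubstituted pyrrolidine or an unsubstituted pyrazole on the same arm would separate the ring from its substituent, and a 4-methylpyrazole would test the chlorine alone.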